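Sulfonyl aryl variation on the shared core: compound 4

The compounds below may be only part of what the source reports. "The series", "measured", "known", "first", "only" and "open" are said of these compounds alone.

Measured compounds:
- compound 1, `COc1ccc2ncc(S(=O)(=O)c3ccc(Cl)c(Cl)c3)c(N3CCC(C)CC3)c2c1`: 87%
- compound 2, `COc1ccc2ncc(S(=O)(=O)c3ccc(C)cc3)c(N3CCC(C)CC3)c2c1`: 90%
- compound 3, `COc1ccc2ncc(S(=O)(=O)c3cc(C)cc(C)c3)c(N3CCC(C)CC3)c2c1`: 79%

All three numbers come from an assay on isolated protein for displacement of a labelled ligand from metabotropic glutamate receptor 5 (Homo sapiens), with a stated time of 60 min, tested at 1 uM; a higher number here means more inhibition at the concentration tested (going by the name of the read-out), a lower number less inhibition. Compound 3 has the lowest of the three, 79%; its nearest neighbour is compound 1, and that gap, a number 8 percentage points lower from compound 1 to compound 3 (within the scatter), lies within the scatter. The gap to compound 2, a number 11 percentage points lower from compound 2 to compound 3 (beyond the scatter), is the only one among the three that is beyond the scatter, so compound 3 can be said to sit somewhat under compound 2 but not under compound 1. Compound 1 and compound 2 are within the scatter of each other, a number 3 percentage points higher from compound 1 to compound 2 (within the scatter).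

Compound 4, `COc1ccc2ncc(S(=O)(=O)c3cccc(Cl)c3)c(N3CCC(C)CC3)c2c1`, is not yet measured in this assay. It differs from compound 3 in one place: 3-chlorophenyl in place of 3,5-dimethylphenyl on a sulfonyl sulfur. The bearing steps are those that reach compound 3. The move from a chlorinated aryl group on the sulfonyl sulfur to the dimethyl one gave a number 8 percentage points lower from compound 1 to compound 3 (within the scatter), and the move from a monosubstituted aryl gave a number 11 percentage points lower from compound 2 to compound 3 (beyond the scatter). Compound 4 returns to a monosubstituted, chlorinated aryl group, so a rise back toward the level of compound 1 and compound 2 is expected, modest in size. Compound 4 is therefore estimated at 85%, range 72% to 94%, which means an expected step of a number 6 percentage points higher from compound 3 to compound 4 (within the scatter).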

Compound 4, a percentage reported as inhibition, at one concentration (the size of the read-out at that concentration, not a potency): -3%
Estimate against measurement, compound 4: 88 percentage points above; the measured number lies below the stated range.
By their numbers in this assay, from the lowest: compound 4; then compounds 3, 1 and 2 (each within the scatter of the next, the first and the last beyond it).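

In this assay, for the compounds shown here, the aryl group on the sulfonyl sulfur proves far less forgiving than the earlier compounds suggested: hydrogen in place of one chloro on an aromatic carbon gives a number 90 percentage points lower from compound 1 to compound 4 (beyond the scatter) and leaves essentially no inhibition. A change of aryl substituents, which altered the number only slightly or modestly among compound 1, compound 2 and compound 3, can here separate strong inhibition from none, with a number 82 percentage points lower from compound 3 to compound 4 (beyond the scatter) for the swap from 3,5-dimethylphenyl to 3-chlorophenyl and a number 93 percentage points lower from compound 2 to compound 4 (beyond the scatter) for the swap from 4-methylphenyl to 3-chlorophenyl. Nothing available explains this loss.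

Compound 1 also carries chloro, so the presence of chloro alone does not mark the compound with the lowest number. Still open, from the compounds shown here alone, is whether the loss is specific to 3-chlorophenyl, and what a plain phenyl, 3-methylphenyl or 3-aminophenyl group on the sulfonyl sulfur would give.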